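The compounds below may be only part of what the source reports. "The series", "measured", "known", "first", "only" and "open" are said of these compounds alone.

Three compounds built on a shared core were tested in an assay on CHO cells for displacement of a labelled ligand from adenosine receptor A1 (Homo sapiens), read by scintillation counting, with a stated time of 90 min, in the presence of a further agent that is not named here; on this read-out lower numbers stand for stronger inhibition and higher numbers for weaker inhibition. Compound 1 `CCCn1c(=O)[nH]c2nc(-c3ccc(S(=O)(=O)N4CCN(Cc5ccc(Br)cc5)CC4)cc3)[nH]c2c1=O` carries a 4-bromobenzyl group on an amine nitrogen in a ring, and in this assay compound 1 gives > 1000 nM, which is a limit of the assay and not a number. Compound 2 `CCCn1c(=O)[nH]c2nc(-c3ccc(S(=O)(=O)N4CCN(c5cccc(F)c5)CC4)cc3)[nH]c2c1=O` bears a 3-fluorophenyl group at that nitrogen, and in this assay compound 2 gives > 1000 nM, again only a limit. Compound 3 `CCCn1c(=O)[nH]c2nc(-c3ccc(S(=O)(=O)N4CCN(c5ccc(F)cc5)CC4)cc3)[nH]c2c1=O` bears a 4-fluorophenyl group there, and in this assay compound 3 gives > 1000 nM, also a limit. The steps a step that the two limits leave unreadable from compound 1 to compound 2, a step that the two limits leave unreadable from compound 1 to compound 3 and a step that the two limits leave unreadable from compound 2 to compound 3 are unreadable because of the limit of > 1000 nM in this assay, at which 3 of the 3 values shown sit. Compound 3 therefore stands at the same limit as the other two, with no number of its own. Compound 4 `CCCn1c(=O)[nH]c2nc(-c3ccc(S(=O)(=O)N4CCN(Cc5cccc(C)c5)CC4)cc3)[nH]c2c1=O` differs from compound 3 by 3-methylbenzyl in place of 4-fluorophenyl on an amine nitrogen in a ring. For the measured compounds named here, none of the measured steps gives a readable size that bears on this change, so no direction beyond the scatter can be drawn from them. Compound 4 is expected to give about 3000 nM in this assay, with a likely range from 800 nM to 15000 nM. The step that this estimate implies is expected to be a step that the limit leaves unreadable from compound 3 to compound 4.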

Compound 4, inhibition constant: 795 nM
Estimate against measurement, compound 4: 3.8-fold (0.58 log units) above; the whole stated range lies above it.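

For the compounds shown here, at the amine nitrogen in the ring, 3-methylbenzyl gives the only reading in this assay that is a number and not a limit, so a group at this position can bring a compound of the series into the readable range. Against the other three groups, the change reads as an at least 1.2-fold lower number from compound 3 to compound 4 (0.09 log units; that floor lies within the scatter) and an at least 1.2-fold lower number from compound 2 to compound 4 (0.09 log units; that floor lies within the scatter) and an at least 1.2-fold lower number from compound 1 to compound 4 (0.09 log units; that floor lies within the scatter) and thus gives only floors, none of them beyond the scatter. The true size of each step stays hidden: the limit of > 1000 nM in this assay, at which 3 of the 4 values shown sit.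

The compounds shown do not separate the effect of the methyl group from that of its place on the benzyl ring, since compound 4 and compound 1 differ in both. On these data alone, how a plain benzyl or a 3-methoxybenzyl group would read at this nitrogen remains open.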